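Chain extension beyond the tetrazolylpropyl ketone of compound 3

The source may report more compounds than this note shows. Statements on the series, on what has been measured and on what is new or still open speak of the compounds shown alone.

Measured so far:
compound 1, `CCCc1c(COc2ccc(C(=O)C(C)(C)Cc3nnn[nH]3)cc2)ccc(C(C)=O)c1O`, 6.93
compound 2, `CCCc1c(COc2ccc(C(=O)CCCC(=O)O)cc2)ccc(C(C)=O)c1O`, 6.81
compound 3, `CCCc1c(COc2ccc(C(=O)CCCc3nnn[nH]3)cc2)ccc(C(C)=O)c1O`, 7.67

In a functional assay on ileum (Cavia porcellus) with cysteinyl leukotriene receptor (Homo sapiens) as the target (a higher number here means a more potent compound, by a factor of ten per unit of this negative logarithm, a lower number a less potent compound), compound 3 stands highest of the three numbers. Its nearest neighbour is compound 1, and the step of a number 0.74 log units higher from compound 1 to compound 3 (beyond the scatter) lies beyond the scatter; the step of a number 0.86 log units higher from compound 2 to compound 3 (beyond the scatter) is of similar size. The step of a number 0.12 log units lower from compound 1 to compound 2 (within the scatter), in contrast, stays within the scatter, so compounds 1 and 2 cannot be ordered against each other.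

Compound 4, `CCCc1c(COc2ccc(C(=O)CCCCc3nnn[nH]3)cc2)ccc(C(C)=O)c1O`, has not yet been measured. It differs from compound 3 by a single change: (1H-tetrazol-5-yl)methyl in place of 1H-tetrazol-5-yl on a saturated chain carbon, three bonds along the chain from a carbonyl carbon. In effect the saturated chain between the carbonyl and the tetrazole grows by one carbon.

Among the compounds with values here, none of the measured steps changes the chain length alone. The step from compound 2 to compound 3 swaps the terminal group at a fixed spacing, and the step from compound 1 to compound 3 alters both spacing and branching at once. Within the data shown here, there is therefore no direct precedent for compound 4, and the expected step of a number 0.27 log units lower from compound 3 to compound 4 (within the scatter) is set small and slightly downward, reflecting uncertainty rather than a measured trend. For compound 4 in this assay the estimate is 7.4, with a range from 6.8 to 8.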

Compound 4, negative logarithm of the antagonist equilibrium constant: 7.28
Beside the measured number, compound 4's estimate is 0.12 log units above it; the measured number falls inside the stated range.
By their numbers in this assay, from the lowest: compounds 2 and 1 (each within the scatter of the next); then compound 4; then compound 3.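

In this assay, within the data shown here, 4-(1H-tetrazol-5-yl)butyl in place of 3-(1H-tetrazol-5-yl)propyl on the carbonyl carbon gives a number 0.39 log units lower from compound 3 to compound 4 (beyond the scatter); this is the first step that alters chain length alone, and it shows that this position responds to chain length even with the terminal tetrazole unchanged. The longer chain does not cancel the standing of the tetrazole series, as the change from the carboxy chain gives a number 0.47 log units higher from compound 2 to compound 4 (beyond the scatter) and the change from the branched chain gives a number 0.35 log units higher from compound 1 to compound 4 (beyond the scatter), although each of these steps alters more than a single feature of the chain. Compound 3 therefore remains the most potent of the four, so among the chains shown the 3-(1H-tetrazol-5-yl)propyl group gives the highest number. Nothing available explains why the number responds to chain length in this way.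

Whether the number keeps falling with a 5-(1H-tetrazol-5-yl)pentyl chain, or also falls with a shorter 2-(1H-tetrazol-5-yl)ethyl chain, remains open, so the compounds shown do not establish a trend. A 4-carboxybutyl chain would be needed to tell whether the carboxylic acid series follows the same dependence on length as the tetrazoles.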